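This account rests on a few compounds, and the source may have more. Where it says the series, first, only, none or still open, it means among the compounds named here.

Two pairs of compounds share one structural change. Compound 1 `COc1ccc(C2N=C(SCc3cccc(Cl)c3)NC(C)=C2C(=O)Nc2ccc(Br)cc2)cc1` and compound 2 `COc1ccc(C2N=C(SCc3ccc(Cl)cc3)NC(C)=C2C(=O)Nc2ccc(Br)cc2)cc1` differ in that (4-chlorophenyl in place of 3-chlorophenyl on a saturated chain carbon bound to a sulfur). In a functional assay on the whole organism (artery, strain albino) with Rattus norvegicus as the target, with a stated time of 900 min, at a dose of 10 mg/kg by the oral route (on this read-out lower numbers stand for less inhibition and higher numbers for more inhibition at the one dose given (going by the name of the read-out)), compound 1 gives 22.6%, and in this assay compound 2 gives 20%, so a number 2.6 percentage points lower from compound 1 to compound 2 (within the scatter). Compound 3 `CC1=C(C(=O)Nc2ccc([N+](=O)[O-])cc2)C(c2ccc(Br)cc2)N=C(SCc2cccc(Cl)c2)N1` carries a different core; the difference between the two cores is not broken down here. In this assay compound 3 gives 2.6%, the lowest of the three measured numbers. Compound 4 `CC1=C(C(=O)Nc2ccc([N+](=O)[O-])cc2)C(c2ccc(Br)cc2)N=C(SCc2ccc(Cl)cc2)N1` is the unmeasured partner of compound 3, and (4-chlorophenyl in place of 3-chlorophenyl on a saturated chain carbon bound to a sulfur), the same kind of change as before, at the same place. Because the earlier step of a number 2.6 percentage points lower from compound 1 to compound 2 (within the scatter) stayed within the scatter, the step of a number 0.4 percentage points higher from compound 3 to compound 4 (within the scatter) is expected to be small as well. Compound 4 is therefore estimated to give 3% in this assay.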

Compound 4, a percentage reported as inhibition, in the whole organism at one dose (the size of the read-out at that dose, not a potency): 19%
Compound 4: middle estimate off by 16 percentage points, on the low side; the measured number lies above the stated range.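

Putting 4-chlorophenyl in place of 3-chlorophenyl on the core of compound 3 gives, in this assay, a number 16.4 percentage points higher from compound 3 to compound 4 (beyond the scatter). The same change therefore does not carry over evenly from one core to the other, and a small step on one core was a poor guide to the step on the other: the same change on two cores in this assay, a number 2.6 percentage points lower (within the scatter) from compound 1 to compound 2 and a number 16.4 percentage points higher (beyond the scatter) from compound 3 to compound 4, 19 percentage points apart, beyond the scatter of two such steps. Within the data shown here, with only two pairs, this does not show which part of the core matters, since the two cores differ in more than one place, nor how the change would behave on any further core.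

All four compounds carry a chlorophenyl group on that chain carbon. As far as these compounds go, it remains open how either core would respond to an amine or a carboxylic acid in place of the chlorine.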